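The compounds below may be only part of what the source reports. "The series", "measured", "known", "first", "only" and "open" are said of these compounds alone.

Compound 1 `COc1cc2c(/C=C3/C(=O)Nc4ccc(O)cc43)c(Cl)n(Cc3cc(OC)c(OC)c(OC)c3)c2cc1C` stands second highest of the three numbers in a functional assay on cells (Cancer cell lines, Homo sapiens) for cytotoxicity, with a stated time of 48 h (on this read-out lower numbers stand for stronger inhibition of growth and higher numbers for weaker inhibition of growth), where compound 1 gives 43700 nM. Compound 3 `O=C1/C(=C/c2c(Cl)[nH]c3ccccc23)c2ccccc2N1Cc1ccccc1` gives 79400 nM, within the scatter of compound 1, while compound 2 `COc1cc2c(/C=C3/C(=O)Nc4ccc(Cl)cc43)c(Cl)n(Cc3cc(OC)c(OC)c(OC)c3)c2cc1C` gives 13800 nM. Compound 4 `COc1cc2c(/C=C3/C(=O)Nc4cccc(Cl)c43)c(Cl)n(Cc3cc(OC)c(OC)c(OC)c3)c2cc1C` is not yet measured; it differs from compound 1 by a group of 12 heavy atoms (9 carbon, 1 nitrogen, 1 oxygen, 1 chlorine; one five-membered non-aromatic ring with 1 hetero atom, one six-membered aromatic ring of carbon only) in place of a group of 12 heavy atoms (9 carbon, 1 nitrogen, 2 oxygen; one five-membered non-aromatic ring with 1 hetero atom, one six-membered aromatic ring of carbon only), on an aromatic carbon, an exchange of hydroxy for chloro on the oxindole ring, as in compound 2 though not at the same ring carbon. Going by the values given here, the one measured step bearing on this is a 3.2-fold lower number from compound 1 to compound 2 (0.50 log units; beyond the scatter), a modest drop beyond the scatter. A step of similar size and direction is expected, a 2.9-fold lower number from compound 1 to compound 4 (0.46 log units; beyond the scatter). Compound 4 is therefore estimated at 15000 nM in this assay, with a range of 6000 nM to 40000 nM.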

Compound 4, concentration for total growth inhibition: 22900 nM
Compound 4: middle estimate off by 1.5-fold (0.18 log units), on the low side; measured number inside the range.
By their numbers in this assay, from the lowest: compounds 2, 4, 1 and 3 (each within the scatter of the next, the first and the last beyond it).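

In this assay, placing the chloro group on a different aromatic carbon gives a 1.7-fold higher number from compound 2 to compound 4 (0.22 log units; within the scatter), so compound 2 and compound 4 cannot be separated by placement. Against the hydroxy group the step is a 1.9-fold lower number from compound 1 to compound 4 (0.28 log units; within the scatter), so compound 4 does not repeat the clear separation of compound 2 from compound 1. No measurement on hand accounts for these numbers.

Still open, as far as these compounds go, is how an amine or a carboxylic acid on this aromatic carbon would compare with the chloro and hydroxy groups.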